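The compounds below may be only part of what the source reports. "The series", "measured", "known", "first", "only" and "open" are said of these compounds alone.

Compound 1 `O=S(=O)(Nc1ccc(-c2nc3ccccc3o2)cc1)c1cccs1` is a sulfonamide whose sulfonyl sulfur carries a thiophen-2-yl group. In an ADME assay on HEK293 cells (Homo sapiens) for cytotoxicity, read by resazurin assay, with a stated time of 48 h (on this read-out lower numbers stand for higher toxicity in this test and higher numbers for lower toxicity in this test), compound 1 gives > 100000 nM, which is a limit of the test rather than a number. Compound 1 thus stands at the limit of > 100000 nM in this assay, at which 1 of the 3 values shown sits. Two measured neighbours carry other groups on the sulfonyl sulfur: compound 2 `O=S(=O)(Nc1ccc2oc(-c3ccccc3)nc2c1)c1ccccc1O` gives 33000 nM, and compound 3 `C=Cc1ccc(S(=O)(=O)Nc2ccc3oc(-c4ccccc4)nc3c2)cc1` gives 53000 nM. The step of a 1.6-fold higher number from compound 2 to compound 3 (0.21 log units; within the scatter) shows that exchanging one aryl group for another there gave a step within the scatter. Compound 4 `O=S(=O)(Nc1ccc(-c2nc3ccccc3o2)cc1)c1cccc(O)c1` differs from compound 1 by 3-hydroxyphenyl in place of thiophen-2-yl on a sulfonyl sulfur. For the measured compounds named here, since only that one small step bears on this change, no step beyond the scatter is expected, and compound 4 is estimated at 100000 nM, within 40000 nM to 250000 nM, meaning a number no higher from compound 1 to compound 4 (the limit leaves the size open).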

Compound 4, half-maximal cytotoxic concentration: > 100000 nM
Compound 4: no number, only a limit; the forecaster's own chance of this, stated with the estimate: 55%; the middle value lies on the limit itself.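

Compound 1 and compound 4 both sit at a limit of this assay, not at a number, so no step can be read between them: the limit of > 100000 nM in this assay, at which 2 of the 4 values shown sit.

Which of thiophen-2-yl and 3-hydroxyphenyl on the sulfonyl sulfur goes with the higher number stays open.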